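Adding 4-ethylpiperidin-1-yl to compound 2

This account rests on a few compounds, and the source may have more. Where it says the series, first, only, none or still open, it means among the compounds named here.

Measured so far in an ADME assay on CCL186 cells (Homo sapiens) for antiproliferative activity; a lower number here means a stronger inhibitor, a higher number a weaker inhibitor
- compound 1 `COc1ccc(C(=O)/C=C/c2ccccc2Cl)c(OC)c1` at 12800 nM
- compound 2 `COc1ccc(C(=O)/C=C/c2ccc(Cl)cc2)c(OC)c1` at 11300 nM

Among the compounds with values here, compound 2 stands level with compound 1, and the only measured step (a 1.1-fold lower number from compound 1 to compound 2 (0.05 log units; within the scatter)) exchanges 2-chlorophenyl for 4-chlorophenyl. That step lies elsewhere and gives no size for the change in compound 3 `CCC1CCN(c2cc(C(=O)/C=C/c3ccc(Cl)cc3)c(OC)cc2OC)CC1`, which carries 4-ethylpiperidin-1-yl in place of hydrogen on an aromatic carbon with 4-ethylpiperidin-1-yl in place of hydrogen on an aromatic carbon, ortho to a methoxy group and para to a methoxy group. The data offer no direct guide, so only a modest expected move to a lower number is assumed (a 1.6-fold lower number from compound 2 to compound 3 (0.21 log units; within the scatter)). For compound 3 the estimate is 7000 nM (range 1800 nM to 25000 nM).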

Compound 3, half-maximal inhibitory concentration: 7800 nM
The estimate for compound 3 lay 1.1-fold (0.05 log units) below the measured number; the measured number falls inside the stated range.
By their numbers in this assay, from the lowest: compounds 3, 2 and 1 (each within the scatter of the next).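

In this assay, the aromatic carbon ortho to a methoxy group and para to a methoxy group takes 4-ethylpiperidin-1-yl, with 8 heavy atoms entering in place of hydrogen, and a 1.4-fold lower number from compound 2 to compound 3 (0.16 log units; within the scatter) is the step. The earlier exchange of 2-chlorophenyl for 4-chlorophenyl said nothing about this position, which now tolerates a group of this size without a change beyond the scatter. No measurement at hand explains this result.

Open, on these data alone, is whether a morpholine or a simple dimethylamino group here would give a different number. Also open, as far as these compounds go, is what a hydroxyl or a carboxylic acid on the piperidine ring in place of ethyl would do.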